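A few compounds are considered here, and "the series" means these few. Any claim that something is new, unique, unknown or untested is made for them only; others in the source may bear on it.

The measured compounds:

compound 1, `C=CC(=O)N1C(=O)CC(c2ccc(C(F)(F)F)cc2)Sc2ccccc21`, 76300 nM
compound 2, `C=CC(=O)N1C(=O)CC(c2ccc(OC)cc2)Sc2ccccc21`, 83200 nM
compound 3, `C=CC(=O)N1C(=O)CC(c2ccc([N+](=O)[O-])cc2)Sc2ccccc21`, 91500 nM

All three numbers come from a functional assay on MOLT-4 cells (Homo sapiens) for cytotoxicity, read by CCK-8 assay, with a stated time of 24 h; a lower number here means a stronger inhibitor, a higher number a weaker inhibitor. Compound 1 gives the lowest of the three, but only just: a 1.1-fold higher number from compound 1 to compound 2 (0.04 log units; within the scatter) and a 1.2-fold higher number from compound 1 to compound 3 (0.08 log units; within the scatter) both fall within the scatter, as does a 1.1-fold higher number from compound 2 to compound 3 (0.04 log units; within the scatter). In practice the three compounds cannot be told apart on these numbers.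

Compound 4, `C=CC(=O)N1C(=O)CC(c2ccc(C(=O)OC)cc2)Sc2ccccc21`, has not yet been measured. It differs from compound 1 in one place: methoxycarbonyl in place of trifluoromethyl on an aromatic carbon. Within the data shown here, every measured step so far swaps one group for another at this same place on the aromatic ring, and none of those swaps moved the number beyond the scatter. The new change is of the same kind, so no step beyond the scatter is expected in this assay in either direction.

Compound 4 is therefore expected to give about 80000 nM in this assay, within a range from 40000 nM to 160000 nM. That estimate corresponds to an expected step of a 1.0-fold higher number from compound 1 to compound 4 (0.02 log units; within the scatter).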

Compound 4, half-maximal inhibitory concentration: 79600 nM
Compound 4: middle estimate off by 1.0-fold (0.00 log units), on the high side, and the stated range covers the measured number.
By their numbers in this assay, from the lowest: compounds 1, 4, 2 and 3 (each within the scatter of the next).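

In this assay, methoxycarbonyl adds hydrogen-bond acceptors at this aromatic carbon, where trifluoromethyl has none, yet the step is a 1.0-fold higher number from compound 1 to compound 4 (0.02 log units; within the scatter). The comparisons with the other two groups read the same way, at a 1.1-fold lower number from compound 3 to compound 4 (0.06 log units; within the scatter) and a 1.0-fold lower number from compound 2 to compound 4 (0.02 log units; within the scatter), so the ester fits the flat picture that the first three compounds gave, and all four groups at this place now lie within the scatter of one another. No supporting measurement is available to explain this flat result.

As far as these compounds go, whether an amine, a carboxylic acid or a longer chain at this place would give a step beyond the scatter remains open. From the compounds shown here alone, all four compounds also share the same core, so the effect of a change elsewhere on it is open too.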